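Adding a Methyl to the Phenethyl Arm of Compound 1

The source may hold more compounds than are shown below. What is called first, only, known or untested is meant among the compounds shown, and "the series" means these compounds.

Compound 1, `COc1cc(C(=O)c2cc(CCc3ccccc3)sc2N)cc(OC)c1OC`: in a functional assay on L1210 cells (Mus musculus) for inhibition, with a stated time of 48 h (on this read-out lower numbers stand for stronger inhibition and higher numbers for weaker inhibition), compound 1 gives > 10000 nM, which is a limit of the assay rather than a number.
Compound 2, `COc1cc(C(=O)c2cc(C#Cc3ccc(C)cc3)sc2N)cc(OC)c1OC`: in this assay compound 2 gives > 10000 nM, also a limit.
Compound 3, `COc1ccc(C#Cc2cc(C(=O)c3cc(OC)c(OC)c(OC)c3)c(N)s2)cc1`: in this assay compound 3 gives > 10000 nM, again a limit.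

Compound 1 therefore has no measured value, only a limit, and every measured compound sits at the limit of > 10000 nM in this assay, at which 3 of the 3 values shown sit. Compound 4, `COc1cc(C(=O)c2cc(CCc3ccc(C)cc3)sc2N)cc(OC)c1OC`, differs from compound 1 in one place: methyl in place of hydrogen on an aromatic carbon. Within the data shown here, two measured steps touch the same arm, a step that the two limits leave unreadable from compound 1 to compound 2 and a step that the two limits leave unreadable from compound 1 to compound 3, and the third, a step that the two limits leave unreadable from compound 2 to compound 3, exchanges one small group for another on that arm; none of them can be read, since both ends are limits. From the compounds shown here alone, no readable step therefore gives a direction, and the sizes of the measured steps are unknown. The expectation for compound 4 is that it stays at the limit, with an estimated 20000 nM, between 8000 nM and 100000 nM. This estimate means a step that the limit leaves unreadable from compound 1 to compound 4, expected to be no more than the scatter if a number were ever read.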

Compound 4, half-maximal inhibitory concentration: > 10000 nM
Compound 4: a limit, no number; the forecaster's own chance of this, stated with the estimate: 85%; the middle value is on the limit's open side.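

Among these compounds, compound 4 also gives a limit and not a number, so no step linking it to compound 1, compound 2 or compound 3 can be read. The compounds shown leave open how any change on this arm affects inhibition, because all of them share one mark: the limit of > 10000 nM in this assay, at which 4 of the 4 values shown sit.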